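Aryl to benzyloxy swap on two related cores

The compounds below may be only part of what the source reports. "The series", "measured", "known", "first", "only" and "open" are said of these compounds alone.

In a functional assay on SK-MEL-2 cells (Homo sapiens) for inhibition, with a stated time of 72 h (on this read-out higher numbers stand for weaker inhibition and lower numbers for stronger inhibition), compound 1 `CC1(c2ccccc2)CC(=O)C(C2CC(c3ccc(-c4ccc(Br)cc4)cc3)Cc3ccccc32)=C(O)O1` gives 2050 nM. Compound 2 `CC1(c2ccccc2)CC(=O)C(C2CC(c3ccc(OCc4ccc(C(F)(F)F)cc4)cc3)Cc3ccccc32)=C(O)O1` returns only a limit in this assay, reported as > 10000 nM. The change (4-(trifluoromethyl)benzyl)oxy in place of 4-bromophenyl on an aromatic carbon thus produces an at least 4.8-fold higher number from compound 1 to compound 2 (0.68 log units; beyond the scatter), a step that is known only as a lower bound since it sits at the limit of > 10000 nM in this assay, at which 2 of the 3 values shown sit. Compound 3 `CCCC1(CCc2ccccc2)CC(=O)C(C2CC(c3ccc(-c4ccc(Br)cc4)cc3)Cc3ccccc32)=C(O)O1` also returns only a limit in this assay, namely > 10000 nM. The difference between the core of compound 3 and the core of compound 1 is not broken down here. Compound 4 `CCCC1(CCc2ccccc2)CC(=O)C(C2CC(c3ccc(OCc4ccc(C(F)(F)F)cc4)cc3)Cc3ccccc32)=C(O)O1` has not been measured; it differs from compound 3 by (4-(trifluoromethyl)benzyl)oxy in place of 4-bromophenyl on an aromatic carbon, the same change that took compound 1 to compound 2, with identical surroundings at the place of attachment. For compound 4 the expected step is a step that the limit leaves unreadable from compound 3 to compound 4, resting on the step of an at least 4.8-fold higher number from compound 1 to compound 2 (0.68 log units; beyond the scatter), which went toward weaker inhibition, and on the fact that compound 3 is already reported only at a limit. Compound 4 is therefore expected to return a limit again, with an estimate of 30000 nM.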

Compound 4, half-maximal inhibitory concentration: > 10000 nM
Compound 4: a limit, no number; the forecaster's own chance of this, stated with the estimate: 90%; the middle value lies beyond the limit too.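

No step can be read from compound 3 to compound 4, because both are reported only as limits in this assay: the limit of > 10000 nM in this assay, at which 3 of the 4 values shown sit.

Still open, on these data alone, is how far (4-(trifluoromethyl)benzyl)oxy in place of 4-bromophenyl shifts inhibition on the core of compound 3, and whether that shift matches the one on the core of compound 1.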